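Terminal amine swap at the end of a hexyl ether chain

The source may report more compounds than this note shows. Statements on the series, on what has been measured and on what is new or still open speak of the compounds shown alone.

Compound 1, `CN(C)CCCCCCCCCCOc1ccc2oc(-c3ccccc3)cc(=O)c2c1`, in an assay on isolated protein (Cavia porcellus) with Sigma non-opioid intracellular receptor 1 (Homo sapiens) as the target, read by radioligand binding (a higher number here means a weaker inhibitor, a lower number a stronger inhibitor), gives 297 nM.
Compound 2, `O=c1cc(-c2ccccc2)oc2ccc(OCCCN3CCC(O)CC3)cc12`, in this assay gives 130 nM.
Compound 3, `O=c1cc(-c2ccccc2)oc2ccc(OCCCCCCN3CCC(O)CC3)cc12`, in this assay gives 100 nM.

Compound 3 has the lowest of the three numbers in this assay, yet its gap to compound 2 is within the scatter, so the two cannot be ranked; only compound 1 stands clearly apart, with a 3.0-fold lower number from compound 1 to compound 3 (0.47 log units; beyond the scatter).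

The step to compound 4, `O=c1cc(-c2ccccc2)oc2ccc(OCCCCCCN3CCNCC3c3ncccn3)cc12`, makes one change: 2-(pyrimidin-2-yl)piperazin-1-yl in place of 4-hydroxypiperidin-1-yl on a saturated chain carbon, six bonds along the chain from an oxygen on an aromatic ring.

For the measured compounds named here, none of the measured steps tests this kind of change. The two that touch the chain end, a 2.3-fold lower number from compound 1 to compound 2 (0.36 log units; beyond the scatter) and a 3.0-fold lower number from compound 1 to compound 3 (0.47 log units; beyond the scatter), replace a dimethylamino chain end with a hydroxypiperidine, both modest. The step of a 1.3-fold lower number from compound 2 to compound 3 (0.11 log units; within the scatter) alters only chain length and is within the scatter. Going by the values given here, every change so far at the chain end has moved the number only modestly, and no measured compound carries an aromatic ring on the terminal amine, so direction is uncertain.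

For compound 4 the expected result is 80 nM, in a range from 20 nM to 400 nM. That estimate amounts to a 1.3-fold lower number from compound 3 to compound 4 (0.10 log units; within the scatter), a step of no clear direction beyond the scatter.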

Compound 4, half-maximal inhibitory concentration: 1630 nM
Compound 4: the middle estimate sits 20-fold (1.31 log units) below what was measured, and the stated range ends below it.
By their numbers in this assay, from the lowest: compounds 3 and 2 (each within the scatter of the next); then compound 1; then compound 4.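

For the compounds shown here, this chain end, six bonds along the chain from an oxygen on an aromatic ring, turns out to be far less tolerant of change than the earlier compounds suggested: in this assay, putting 2-(pyrimidin-2-yl)piperazin-1-yl in place of 4-hydroxypiperidin-1-yl gives a 16-fold higher number from compound 3 to compound 4 (1.21 log units; beyond the scatter) and is the first large step. The earlier steps shown here were modest or within the scatter, and all of them led to lower numbers or left the number unresolved, whereas this one clearly moves toward a weaker inhibitor. The new group also falls behind the simple dimethylamino chain end, with a 5.5-fold higher number from compound 1 to compound 4 (0.74 log units; beyond the scatter) in the same assay, so a terminal amine alone does not secure the lower numbers, and no measurement here explains the loss.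

On these data alone, whether the loss comes from the pyrimidin-2-yl ring or from the piperazine that carries it remains open. A plain piperazin-1-yl or a 2-phenylpiperazin-1-yl on the same hexyl chain would help separate the two, and a propyl chain carrying 2-(pyrimidin-2-yl)piperazin-1-yl would show whether chain length matters for this group.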